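The source may hold more compounds than are shown below. What is called first, only, known or untested is meant among the compounds shown, and "the series" means these compounds.

Compounds measured in a toxicity assay on HUVEC cells (Homo sapiens) for inhibition; a higher number here means a weaker inhibitor of growth, a lower number a stronger inhibitor of growth:

- compound 1 `Cc1nc(-c2ccccc2)c(C(=O)N2CCN(c3cccc(Cl)c3)CC2)o1` gives 0.463 ug/mL
- compound 2 `CCC[C@H](Nc1nc(-c2ccc(NC(=O)NCC)c(OC)c2)ncc1C)c1cccnc1` gives 2.1 ug/mL
- compound 3 `Cc1nc(-c2ccccc2)c(C(=O)N2CCN(c3cc(Cl)cc(Cl)c3)CC2)o1` gives 0.191 ug/mL

Among the measured compounds shown here, of these three numbers, the one for compound 1 is the second highest, with compound 3 lower and compound 2 higher. The step now in view leads to compound 4 `Cc1nc(-c2ccccc2)c(C(=O)N2CCN(c3ccccc3)CC2)o1`, which has not yet been measured. The change is hydrogen in place of chloro on an aromatic carbon. For the measured compounds named here, only one measured step bears on it, namely a 2.4-fold lower number from compound 1 to compound 3 (0.38 log units; beyond the scatter), where chloro takes the place of hydrogen on an aromatic carbon. That step is modest but beyond the scatter. It is the same kind of change run in the opposite direction, although not at the same carbon, so it offers only a rough guide. Compound 2 differs too widely to inform this comparison. A modest move in this assay towards a higher number is therefore expected, and the estimated step is a 2.2-fold higher number from compound 1 to compound 4 (0.33 log units; beyond the scatter). The estimate for compound 4 is 1 ug/mL, with an expected range from 0.4 ug/mL to 2.5 ug/mL.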

Compound 4, concentration for 50% growth inhibition: 9.63 ug/mL
Estimate against measurement, compound 4: 9.6-fold (0.98 log units) below; the whole stated range lies below it.
By their numbers in this assay, from the lowest: compound 3; then compound 1; then compound 2; then compound 4.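

In this assay, the loss of the lone chloro proves to be a large step, a 21-fold higher number from compound 1 to compound 4 (1.32 log units; beyond the scatter), and it far exceeds the modest step seen on adding a further chloro, a 2.4-fold lower number from compound 1 to compound 3 (0.38 log units; beyond the scatter). Among these three compounds, the number falls with each chloro on the aromatic ring, and most of the overall span, a 50-fold higher number from compound 3 to compound 4 (1.70 log units; beyond the scatter), lies between 3-chlorophenyl and phenyl; compound 2 differs too widely to test this pattern. Nothing shown here accounts for the size of this step.

The compounds shown leave open whether the low number depends on chloro itself or would also hold with fluoro, bromo, methyl or methoxy on the same carbon. They also leave open how a single chloro would behave on any other carbon of that ring.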